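The source may report more compounds than this note shows. Statements on the series, on what has been measured and on what is new or still open speak of the compounds shown alone.

Three compounds have been measured in a functional assay on SMMC-7721 cells (Homo sapiens) for cytotoxicity, read by MTT assay, with a stated time of 72 h; a higher number here means a weaker inhibitor, a lower number a stronger inhibitor:
compound 2, `CCCCCOCNc1n[n+]([O-])c2ccccc2[n+]1[O-]`, 3050 nM
compound 3, `CCCCCOCNc1n[n+]([O-])c2cc(OC)ccc2[n+]1[O-]`, 550 nM
compound 1, `O=[N+]([O-])c1cccc(COCNc2n[n+]([O-])c3ccccc3[n+]2[O-])c1`, 520 nM

Compound 2 gives the highest number of the three and is therefore the weakest inhibitor shown. Compound 4, `CCCOCNc1n[n+]([O-])c2ccccc2[n+]1[O-]`, differs from it by hydrogen in place of ethyl on a saturated chain carbon, three bonds along the chain from an oxygen on a saturated carbon. Going by the values given here, the only measured step, a 5.5-fold lower number from compound 2 to compound 3 (0.74 log units; beyond the scatter), alters the ring and leaves the pentyl untouched, so it says nothing about shortening that chain. Compound 1 swaps the whole pentyl for another group and gives a lower number, but the chain length itself has not been varied anywhere. With nothing bearing on this change, no movement beyond the scatter is expected in this assay. Compound 4 is therefore estimated at 3000 nM, from 1000 nM to 9000 nM. That estimate means an expected step of a 1.0-fold lower number from compound 2 to compound 4 (0.01 log units; within the scatter).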

Compound 4, half-maximal inhibitory concentration: 5530 nM
Compound 4: middle estimate off by 1.8-fold (0.27 log units), on the low side; the range from low to high includes it.
By their numbers in this assay, from the lowest: compounds 1 and 3 (each within the scatter of the next); then compounds 2 and 4 (each within the scatter of the next).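

Replacing pentyl with propyl gives a 1.8-fold higher number from compound 2 to compound 4 (0.26 log units; within the scatter) in this assay, the first direct test of chain length at this position. Across these two chains, the shortening leaves the number within the usual scatter, so this stretch of the chain shows no clear dependence on length here. No supporting evidence is available to explain this result.

On these data alone, two chain lengths cannot establish a trend, so it remains open whether a longer chain, such as heptyl, would behave alike. A chain carrying an amine or a carboxylic acid also remains untested among the compounds shown.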